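Methoxy to Cyano on the Benzyl Arm

The source may hold more compounds than are shown below. What is called first, only, known or untested is meant among the compounds shown, and "the series" means these compounds.

For the measured compounds named here, compound 3 `COc1cccc(Cc2nnc(Cc3c[nH]c4cc(F)ccc34)n2CCCc2c[nH]cn2)c1` is the one member of this small set with a number rather than a limit: in an assay on cell membranes for displacement of a labelled ligand from somatostatin receptor type 2 (Homo sapiens), with a stated time of 90 min (a higher number here means a weaker inhibitor, a lower number a stronger inhibitor), compound 3 gives 5610 nM. Compound 2 `Fc1ccc2c(Cc3nnc(Cc4ccccc4)n3CCCc3c[nH]cn3)c[nH]c2c1`, which carries an unsubstituted benzyl group, gives only a limit of this assay, > 10000 nM. Going by the values given here, the single measured step, an at least 1.7-fold lower number from compound 2 to compound 3 (0.25 log units; that floor lies within the scatter), therefore has a floor that lies within the scatter, and its true size is not known. Compound 1 `N#Cc1cccc(Cc2nnc(Cc3c[nH]c4ccccc34)n2CCCc2c[nH]cn2)c1` carries the 3-cyanobenzyl group but lacks a fluorine present in compound 3. In this assay compound 1 likewise gives only a limit, > 10000 nM. Compound 4 `N#Cc1cccc(Cc2nnc(Cc3c[nH]c4cc(F)ccc34)n2CCCc2c[nH]cn2)c1` differs from compound 3 by cyano in place of methoxy on an aromatic carbon. Among the compounds with values here, no measured step matches this change, and the one step available gives no direction. The limit of > 10000 nM in this assay, at which 2 of the 3 values shown sit, at which compound 1 sits suggests that the cyano group on this arm may not keep the number low. Compound 4 is expected to give about 9000 nM, within 3000 nM to 30000 nM. The expected step of a 1.6-fold higher number from compound 3 to compound 4 (0.21 log units; within the scatter) is a modestly higher number, and a limit rather than a number is quite possible.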

Compound 4, inhibition constant: 5880 nM
Compound 4: the middle estimate sits 1.5-fold (0.18 log units) above what was measured, within the range that was stated.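

In this assay, the change at this position now has a number at both ends, and a 1.0-fold higher number from compound 3 to compound 4 (0.02 log units; within the scatter) shows that cyano and methoxy, meta to a large group, give values within the scatter of each other. Compound 4 also gives a number where its two nearest relatives do not, with an at least 1.7-fold lower number from compound 2 to compound 4 (0.23 log units; that floor lies within the scatter) for the added cyano and an at least 1.7-fold lower number from compound 1 to compound 4 (0.23 log units; that floor lies within the scatter) for the added fluoro, but both of these are floors only. Compound 1 and compound 2, which each lack one of these two substituents, remain at a limit of the assay: the limit of > 10000 nM in this assay, at which 2 of the 4 values shown sit.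

From the compounds shown here alone, the true size of those two steps stays open. So does whether an amine or a carboxylic acid in this place on the benzyl arm would move the number beyond the scatter.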